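A Pyridine Replaces a Chlorophenyl at the Chain Carbon

The source may report more compounds than this note shows. Statements on the series, on what has been measured and on what is new or still open speak of the compounds shown alone.

The account follows compound 1, `Clc1cccc(Cn2ccc3nc(-c4ccccc4)nc-3c2)c1`, into a single change. In an ADME assay on MDBK cells (Bos taurus) for cytotoxicity (a lower number here means that less compound is tolerated, a higher number that more compound is tolerated), compound 1 reaches only the limit of the assay and gives > 100000 nM. Where compound 1 stands can thus be told only as a limit, and among the three values shown a second one is a limit as well, as the limit of > 100000 nM in this assay, at which 2 of the 3 values shown sit, records. Compound 2, `CC(c1ccccc1)n1ccc2nc(-c3ccccc3)nc-2c1`, likewise sits at the limit with > 100000 nM in this assay. Among the compounds with values here, compound 3, `c1ccc(-c2nc3ccn(Cc4cccc5ccccc45)cc-3n2)cc1`, is the one compound with a number: in this assay compound 3 gives 61000 nM.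

The step under study leads to compound 4, `c1ccc(-c2nc3ccn(Cc4ccncc4)cc-3n2)cc1`. Its difference from compound 1 is pyridin-4-yl in place of 3-chlorophenyl on a saturated chain carbon bound to an aromatic nitrogen. Within the data shown here, no pair of measured compounds differs in one place, so no measured step gives a size for this kind of change. With compound 1 and compound 2 both at the limit, the expectation for this assay is no step beyond the usual scatter, most probably with compound 4 again at the limit. Compound 4 is therefore estimated at 100000 nM, with a range from 50000 nM to 300000 nM. The step this estimate means is a number no higher from compound 1 to compound 4 (the limit leaves the size open), expected to be no change beyond the scatter.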

Compound 4, half-maximal cytotoxic concentration: > 100000 nM
Compound 4 gave a limit, no number; the forecaster's own chance of this, stated with the estimate: 70%; the middle value sits exactly at the limit.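

In this assay compound 4 gives > 100000 nM, a limit of the assay and not a number. Compound 1 also stands at a limit, so no step from compound 1 to compound 4 can be read: the limit of > 100000 nM in this assay, at which 3 of the 4 values shown sit.

The compounds shown leave open whether pyridin-4-yl in place of 3-chlorophenyl moves the read-out in this assay at all, and in which direction.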